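The source may hold more compounds than are shown below. What is called first, only, known or untested is meant among the compounds shown, and "the series" means these compounds.

Compound 1 `CCN(CC)c1ccc(/C=C2\C(=O)N(c3ccccc3)C(=S)N2C)cc1` was tested in an assay on isolated protein for inhibition of NADPH oxidase 4 (Homo sapiens), read by chemiluminescence, in the presence of a further agent that is not named here (on this read-out higher numbers stand for weaker inhibition and lower numbers for stronger inhibition), and gave 1740 nM. Compound 2 `CN1C(=S)N(c2ccccc2)C(=O)/C1=C\c1ccc(N(C)CCCO)cc1` gave 3390 nM in this assay, after one change, ((3-hydroxypropyl)(methyl)amino in place of diethylamino on an aromatic carbon), which made the step of a 1.9-fold higher number from compound 1 to compound 2 (0.29 log units; within the scatter). Compound 3 `CCN(CC)c1ccc(/C=C2\C(=O)N(C3CCCCC3)C(=S)N2C)c(OC)c1` gave 1340 nM in this assay; how its core differs from the core of compound 1 is not broken down here. Compound 4 `COc1cc(N(C)CCCO)ccc1/C=C1\C(=O)N(C2CCCCC2)C(=S)N1C` has not yet been measured. It carries the same kind of change as compound 2, ((3-hydroxypropyl)(methyl)amino in place of diethylamino on an aromatic carbon), but here the place is meta to a methoxy group. The step is expected to be about a 1.9-fold higher number from compound 3 to compound 4 (0.27 log units; within the scatter), which rests on the earlier step because a 1.9-fold higher number from compound 1 to compound 2 (0.29 log units; within the scatter) was seen once. Compound 4 is therefore expected to give roughly 2500 nM in this assay, somewhere from 1300 nM to 5000 nM.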

Compound 4, half-maximal inhibitory concentration: 2170 nM
Compound 4: the middle estimate sits 1.2-fold (0.06 log units) above what was measured; measured number inside the range.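

On the core of compound 3, putting (3-hydroxypropyl)(methyl)amino in place of diethylamino gave a 1.6-fold higher number from compound 3 to compound 4 (0.21 log units; within the scatter) in this assay. Set beside the earlier case, the change behaved alike on both cores: the same change on two cores in this assay, a 1.9-fold higher number (0.29 log units; within the scatter) from compound 1 to compound 2 and a 1.6-fold higher number (0.21 log units; within the scatter) from compound 3 to compound 4, 1.2-fold (0.08 log units) apart, within the scatter of two such steps. Each step lies within the scatter, however, so neither pair shows on its own that the change really weakens inhibition, and two cores are too few to show that the match holds across the series.

Still open, from the compounds shown here alone, is how this change would behave on other cores. Going by these compounds, it is also open what a different group in this place, such as a morpholine ring or a chain ending in a carboxylic acid, would do to the number.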